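Swapping the Aryl Group on Nitrogen for a Short Ethyl Chain

A few compounds are considered here, and "the series" means these few. Any claim that something is new, unique, unknown or untested is made for them only; others in the source may bear on it.

Of the compounds shown here, three sharing one core have been tested in an assay on isolated protein for inhibition of methionine--tRNA ligase, cytoplasmic (Homo sapiens); on this read-out higher numbers stand for weaker inhibition and lower numbers for stronger inhibition. Compound 1 `O=C(O)c1cc(-c2ccc(-c3ccc(Cl)cc3Cl)cc2)n(-c2ccc(Cl)cc2Cl)n1` gives 11900 nM in this assay, and compound 2 `O=C(O)c1cc(-c2ccc(-c3ccc(Cl)cc3Cl)cc2)n(-c2cccnc2)n1` gives 47000 nM; the step of a 3.9-fold higher number from compound 1 to compound 2 (0.60 log units; beyond the scatter) lies beyond the scatter. For compound 3 `COc1ccc(-n2nc(C(=O)O)cc2-c2ccc(-c3ccc(Cl)cc3Cl)cc2)cc1` this assay reports only a limit, > 100000 nM. Compound 3 therefore stands at the weak end of the set, as shown by an at least 8.4-fold higher number from compound 1 to compound 3 (0.92 log units; beyond the scatter) and an at least 2.1-fold higher number from compound 2 to compound 3 (0.32 log units; beyond the scatter), both at the edge (the limit of > 100000 nM in this assay, at which 1 of the 3 values shown sits).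

Compound 4 `CCn1nc(C(=O)O)cc1-c1ccc(-c2ccc(Cl)cc2Cl)cc1` carries a much smaller group on the ring nitrogen: ethyl in place of 4-methoxyphenyl on an aromatic nitrogen. The two steps leading into compound 3 both show that changing the group on this nitrogen moves inhibition by a modest amount, and in both cases the change weakened it. Among the compounds with values here, no measured step tells whether a chain rather than a ring will reverse this. For compound 4 the expectation is therefore a step of about a number no higher from compound 3 to compound 4 (the limit leaves the size open) in this assay, close to no change. The estimated value for compound 4 is 100000 nM, with a range from 25000 nM to 400000 nM, and a fair chance that only a limit is reported again.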

Compound 4, half-maximal inhibitory concentration: 46400 nM
Compound 4: middle estimate off by 2.2-fold (0.33 log units), on the high side, within the range that was stated.
By their numbers in this assay, from the lowest: compound 1; then compounds 4 and 2 (each within the scatter of the next). At a limit, above all of these: compound 3.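

Changing 4-methoxyphenyl to ethyl gives an at least 2.1-fold lower number from compound 3 to compound 4 (0.33 log units; beyond the scatter) in this assay, so a readable value on this nitrogen does not depend on an aromatic ring. As far as these compounds go, compound 3 remains a limit of the assay, so the true size of that step stays unknown: the limit of > 100000 nM in this assay, at which 1 of the 4 values shown sits. Ethyl, which has no ring, is level with pyridin-3-yl, at a 1.0-fold lower number from compound 2 to compound 4 (0.01 log units; within the scatter), and only 2,4-dichlorophenyl keeps an edge, with a 3.9-fold higher number from compound 1 to compound 4 (0.59 log units; beyond the scatter).

From the compounds shown here alone, whether a longer chain such as butyl, or a smaller methyl, would bring this nitrogen closer to compound 1 remains open. Also open, going by these compounds, is what a plain phenyl ring would give, which would help separate the contribution of the ring from that of its two chlorine atoms.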